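The compounds below may be only part of what the source reports. "The series", "measured", "known", "first", "only" and "open" are said of these compounds alone.

Working notes on the sulfamate series.

The shared core of compound 3 `CCN(Cc1cccnc1)c1ccc(C(=O)N2CCc3ccc(OS(N)(=O)=O)cc3C2)cc1` carries the amine on the aromatic carbon; in an assay on HEK293 cells for inhibition of Steryl-sulfatase (Homo sapiens), tested at 0.1 uM (on this read-out lower numbers stand for a weaker effect and higher numbers for a stronger effect at the one concentration tested), compound 3 gives 35.7%. Among the three measured compounds it stands second highest: compound 2 `CC(C)CCN(CCC(C)C)c1ccc(C(=O)N2CCc3ccc(OS(N)(=O)=O)cc3C2)cc1` gives 47%, a step of a number 11.3 percentage points lower from compound 2 to compound 3 (beyond the scatter); compound 1 `CN(C)CCN(CCN(C)C)c1ccc(C(=O)N2CCc3ccc(OS(N)(=O)=O)cc3C2)cc1` gives 3.8%, and the steps of a number 31.9 percentage points higher from compound 1 to compound 3 (beyond the scatter) and a number 43.2 percentage points higher from compound 1 to compound 2 (beyond the scatter) show that changing the group on this aromatic nitrogen moves the read-out strongly.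

Compound 4 `CCN(Cc1ccccn1)c1ccc(C(=O)N2CCc3ccc(OS(N)(=O)=O)cc3C2)cc1` differs from compound 3 only by pyridin-2-yl in place of pyridin-3-yl on a saturated chain carbon bound to a nitrogen on an aromatic ring. The two have the same atoms, joined differently. Among the measured compounds shown here, none of the measured steps touches the point of attachment of the pyridine; each of them swaps the whole amine substituent, so there is no direct precedent for this change. The measured steps say only that this region of the molecule is sensitive, not in which direction a shift of the ring nitrogen acts. With nothing to point either way, the expected step of a number 0.7 percentage points lower from compound 3 to compound 4 (within the scatter) is none beyond the scatter, with a wide range to allow for the sensitivity seen between compound 1 and compound 2.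

Compound 4 is therefore estimated at 35%, with a range from 15% to 55%.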

Compound 4, a percentage reported as inhibition, at one concentration (the size of the read-out at that concentration, not a potency): 42.5%
Compound 4: middle estimate off by 7.5 percentage points, on the low side; low and high end bracket the measured number.
By their numbers in this assay, from the lowest: compound 1; then compounds 3, 4 and 2 (each within the scatter of the next, the first and the last beyond it).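

Within this assay, the step of a number 6.8 percentage points higher from compound 3 to compound 4 (within the scatter) is the first measured change that keeps the whole ethyl((pyridinyl)methyl)amino substituent and alters only the point of attachment, and on this read-out pyridin-2-yl and pyridin-3-yl on this saturated chain carbon cannot be told apart. The isomer also alters the picture against the other amines: the step of a number 4.5 percentage points lower from compound 2 to compound 4 (within the scatter) leaves ethyl((pyridin-2-yl)methyl)amino and diisopentylamino unresolved, whereas the step from compound 2 to compound 3 lay beyond the scatter, and the step of a number 38.7 percentage points higher from compound 1 to compound 4 (beyond the scatter) shows that bis(2-(dimethylamino)ethyl)amino remains well apart from this group too, so the sensitivity of this region rests on the swap of the whole amine rather than on the place of the ring nitrogen. Nothing measured here offers a reason for any of these steps.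

Pyridin-4-yl or a plain phenyl ring on the same saturated chain carbon, and a propyl chain in place of the ethyl on the amine nitrogen, remain open. With a single concentration as the only read-out, the compounds shown also leave open how compound 3 and compound 4 compare in potency.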